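From Methoxy to Bromo in a Growth Inhibition Series

The compounds below may be only part of what the source reports. "The series", "measured", "known", "first", "only" and "open" are said of these compounds alone.

In a functional assay on M14 cells (Homo sapiens) for cytotoxicity (on this read-out lower numbers stand for stronger inhibition of growth and higher numbers for weaker inhibition of growth), compound 3 `COc1ccc(C2=C(c3ccc(SC)cc3)CC3CCCN3C2=O)cc1` gives 4000 nM. Compound 1 `COc1ccc(C2=C(c3ccc(SC)cc3)CC3CCCN3C2=O)cc1Br` gives 3000 nM, which is a 1.3-fold higher number from compound 1 to compound 3 (0.12 log units; within the scatter), so the two cannot be told apart. For the measured compounds named here, compound 2 `CSc1ccc(C2=C(c3ccc(F)c(C)c3)C(=O)N3CCCC3C2)cc1` gives 800 nM, the only clearly lower number.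

Compound 4 `CSc1ccc(C2=C(c3ccc(Br)cc3)C(=O)N3CCCC3C2)cc1` keeps the core of compound 3 but has bromo in place of methoxy on an aromatic carbon, para to a large group (bromo in place of methoxy on an aromatic carbon). This turns 4-methoxyphenyl into 4-bromophenyl.

Going by the values given here, two measured steps bear on this change. Compound 1 carries a bromo on the same ring as its methoxy, and removing it gives only a 1.3-fold higher number from compound 1 to compound 3 (0.12 log units; within the scatter). Among the compounds with values here, replacing the whole 4-methoxyphenyl group of compound 3 with the one in compound 2 matters more, as the reverse step shows: a 5.0-fold higher number from compound 2 to compound 3 (0.70 log units; beyond the scatter). Within the data shown here, no measurement yet isolates bromo in this place, so a modest move towards lower numbers in this assay is expected, and it may stay within the scatter. The expected change is a 2.2-fold lower number from compound 3 to compound 4 (0.35 log units; beyond the scatter). For compound 4 the estimate is 1800 nM, with a range from 600 nM to 5000 nM.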

Compound 4, concentration for 50% growth inhibition: 9000 nM
Beside the measured number, compound 4's estimate is 5.0-fold (0.70 log units) below it, and the stated range ends below it.
By their numbers in this assay, from the lowest: compound 2; then compounds 1 and 3 (each within the scatter of the next); then compound 4.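

Putting bromo in place of methoxy on this aromatic carbon moves this assay towards weaker growth inhibition, not stronger (a 2.3-fold higher number from compound 3 to compound 4 (0.35 log units; beyond the scatter)). The bromo of compound 1 sits on a ring that keeps its methoxy, and that ring now compares favourably with 4-bromophenyl (a 3.0-fold higher number from compound 1 to compound 4 (0.48 log units; beyond the scatter)), so a bromo on this ring does not behave the same with and without methoxy. The 4-fluoro-3-methylphenyl group of compound 2 now stands much further from 4-bromophenyl than from 4-methoxyphenyl (an 11-fold higher number from compound 2 to compound 4 (1.05 log units; beyond the scatter)), and nothing available explains any of these differences.

On these data alone, whether the higher number comes from losing methoxy or from gaining bromo stays open, and a hydroxy or an amine at this place would help separate the two. Also open is which part of the 4-fluoro-3-methylphenyl group matters, as fluoro and methyl always travel together in the compounds shown.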